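Branched Ester Amides on a Cinnamate Prodrug: Stability Outlook

This account rests on a few compounds, and the source may have more. Where it says the series, first, only, none or still open, it means among the compounds named here.

Measured compounds:
Compound 1, `CCOc1cc(NC(=O)C2(NC(=O)c3ccc4c(C5CCCC5)c(-c5ncc(Cl)cn5)n(C)c4c3)CCC2)ccc1/C=C/C(=O)OCOP(=O)(O)O`: 0.167 h
Compound 2, `CCOc1cc(NC(=O)C2(NC(=O)c3ccc4c(C5CCCC5)c(-c5ncc(Cl)cn5)n(C)c4c3)CCC2)ccc1/C=C/C(=O)OCC(C)C`: > 5 h
Compound 3, `CCCN(C)C(=O)COC(=O)/C=C/c1ccc(NC(=O)C2(NC(=O)c3ccc4c(C5CCCC5)c(-c5ncc(Cl)cn5)n(C)c4c3)CCC2)cc1OCC`: 0.317 h

All three share one core and differ only in the group attached to the ester oxygen. In an ADME assay (liver) for pharmacokinetics, with Liver microsome (Homo sapiens) as the target, using microsomes (a lower number here means that the compound disappears faster, a higher number that the compound lasts longer), compound 1 gives 0.167 h. Compound 2 reaches only a limit of the assay, > 5 h, and that is all its value tells (the limit of > 5 h in this assay, at which 1 of the 3 values shown sits). Compound 3 gives 0.317 h, the higher of the two real numbers, yet the step of a 1.9-fold higher number from compound 1 to compound 3 (0.28 log units; within the scatter) stays within the scatter, so compound 1 and compound 3 cannot be told apart here. The step of an at least 15-fold lower number from compound 2 to compound 3 (1.19 log units; beyond the scatter) is large.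

Compound 4, `CCOc1cc(NC(=O)C2(NC(=O)c3ccc4c(C5CCCC5)c(-c5ncc(Cl)cn5)n(C)c4c3)CCC2)ccc1/C=C/C(=O)OCC(=O)N(C)C(C)C`, is not yet measured. It differs from compound 3 by isopropyl in place of propyl on an amide-type nitrogen. This is a far smaller change than either measured step, which both swap the whole group on the ester oxygen, so no step beyond the scatter is expected: compound 4 is estimated at 0.35 h, between 0.15 h and 0.9 h, a step of a 1.1-fold higher number from compound 3 to compound 4 (0.04 log units; within the scatter).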

Compound 4, half-life: 0.65 h
Beside the measured number, compound 4's estimate is 1.9-fold (0.27 log units) below it, within the range that was stated.
By their numbers in this assay, from the lowest: compounds 1 and 3 (each within the scatter of the next); then compound 4. At a limit, above all of these: compound 2.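

In this assay, moving from a straight chain to a branched one on the amide-type nitrogen, with the same atoms joined differently, is enough to shift the number: a 2.1-fold higher number from compound 3 to compound 4 (0.31 log units; beyond the scatter). The earlier compounds shown here offered no real number clear of the scatter at the short end, and now there is one: a 3.9-fold higher number from compound 1 to compound 4 (0.59 log units; beyond the scatter). Replacing the whole group on the ester oxygen still counts for more, and this step starts from a limit, not a number, an at least 7.6-fold lower number from compound 2 to compound 4 (0.88 log units; beyond the scatter): the limit of > 5 h in this assay, at which 1 of the 4 values shown sits.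

A single pair cannot show whether branching on this nitrogen raises the number in general. The compounds shown leave open what tert-butyl or cyclopropyl on the same nitrogen would give, and whether either would come closer to compound 2.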